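The compounds below may be only part of what the source reports. "The series", "measured", "known", "first", "only" and "open" are said of these compounds alone.

Three compounds sharing one core have been examined in an ADME assay on NIH3T3 cells (Mus musculus) for cytotoxicity, read by XTT assay, with a stated time of 24 h; on this read-out higher numbers stand for weaker inhibition and lower numbers for stronger inhibition. Compound 1 `Cn1nnnc1SCC(=O)N/N=C/c1ccccc1[N+](=O)[O-]` gives 2020000 nM in this assay. Compound 3 `Cn1nnnc1SCC(=O)N/N=C/c1cccc(Cl)c1Cl` gives 520000 nM in this assay. For compound 2 `Cn1nnnc1SCC(=O)N/N=C/c1ccccc1Cl` this assay reports only a limit, > 10000000 nM, so its true value is not a number but sits at the limit of > 10000000 nM in this assay, at which 1 of the 3 values shown sits. Compound 2 therefore stands as the weakest-looking of the three on the numbers shown, though only as a limit. The step of an at least 4.9-fold higher number from compound 1 to compound 2 (0.69 log units; beyond the scatter) and the step of an at least 19-fold lower number from compound 2 to compound 3 (1.28 log units; beyond the scatter) both start or end at this limit.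

Compound 4 `Cn1nnnc1SCC(=O)N/N=C/c1c(Cl)cccc1Cl` has not yet been measured in this assay. It differs from compound 2 by chloro in place of hydrogen on an aromatic carbon. The closest measured step is an at least 19-fold lower number from compound 2 to compound 3 (1.28 log units; beyond the scatter), which also added chloro in place of hydrogen to compound 2, and it moved the number strongly downward. Since compound 2 sits at a limit, the size of any step from it is itself only a lower bound. Compound 4 is expected to show a lower number than compound 2, with a step estimated as an at least 11-fold lower number from compound 2 to compound 4 (1.04 log units; beyond the scatter). Compound 4 is estimated at 900000 nM, within a range from 200000 nM to 5000000 nM. What this assay actually reports for compound 4 remains to be seen.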

Compound 4, half-maximal inhibitory concentration: > 10000000 nM
Compound 4: no number, only a limit; the forecaster's own chance of this, stated with the estimate: 25%; at least 11-fold (1.04 log units) between middle value and limit.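

In this assay compound 4 gives > 10000000 nM, which is a limit and not a number. Compound 2 also stands at a limit, so no step can be read between compound 2 and compound 4: the limit of > 10000000 nM in this assay, at which 2 of the 4 values shown sit.

The compounds shown leave open where the true values of compound 2 and compound 4 lie, and whether the added chloro in compound 4 changes the read-out at all.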